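Ribose-modified adenosine analogues: carboxy in place of ethylcarbamoyl

The compounds below may be only part of what the source reports. "The series", "measured", "known", "first", "only" and "open" are said of these compounds alone.

Three compounds of the series have numbers in an assay with adenosine receptor A1 (Rattus norvegicus) as the target; a lower number here means a stronger inhibitor, a higher number a weaker inhibitor. Compound 1 `CCNC(=O)[C@H]1OC(n2cnc3c(NC(CC)CC)ncnc32)[C@H](O)[C@@H]1O` gives 1.5 nM in this assay, and compound 2 `COc1ccc(Nc2ncnc3c2ncn3C2O[C@H](C(=O)O)[C@@H](O)[C@H]2O)cc1` gives 1 nM. Compound 3 `CCNC(=O)[C@H]1OC(n2cnc3c(NC)ncnc32)[C@H](O)[C@@H]1O` gives 120 nM, the highest of the three numbers; its nearest neighbour is compound 1 and its furthest compound 2, both gaps well beyond the scatter. Within the data shown here, the only single-point step measured so far is an 80-fold higher number from compound 1 to compound 3 (1.90 log units; beyond the scatter), which concerns the amine substituent and not the ribose end.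

Compound 4 `CNc1ncnc2c1ncn2C1O[C@H](C(=O)O)[C@@H](O)[C@H]1O` is the next member. Relative to compound 3 the change is hydroxy in place of ethylamino on a carbonyl carbon, that is, ethylcarbamoyl to carboxy on the sugar. Among the measured compounds shown here, no measured pair isolates this change: compound 2 carries the carboxy group but also a different amine substituent, so its value of 1 nM and that of compound 3 show only that a carboxy compound can bind tightly when the amine differs, not what the carboxy group itself does. Given that no relevant step exists, a modest weakening is expected for compound 4, a 3.3-fold higher number from compound 3 to compound 4 (0.52 log units; beyond the scatter), with wide uncertainty. The estimate for compound 4 in this assay is 400 nM, in the range 80 nM to 3000 nM.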

Compound 4, half-maximal inhibitory concentration: 68 nM
The estimate for compound 4 lay 5.9-fold (0.77 log units) above the measured number, and the stated range ends above it.
By their numbers in this assay, from the lowest: compounds 2 and 1 (each within the scatter of the next); then compounds 4 and 3 (each within the scatter of the next).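

In this assay there is a 1.8-fold lower number from compound 3 to compound 4 (0.25 log units; within the scatter), so with methyl on the nitrogen on the aromatic ring, hydroxy and ethylamino on the carbonyl carbon cannot be told apart in this series. With the carboxy group held constant, the substituent on that nitrogen matters: there is a 68-fold higher number from compound 2 to compound 4 (1.83 log units; beyond the scatter) and this large step runs the same way as an 80-fold higher number from compound 1 to compound 3 (1.90 log units; beyond the scatter) in the ethylcarbamoyl pair, although the larger substituents in the two pairs are different groups. No independent measurement bears on these results, and the data offer no explanation of them.

Still open, as far as these compounds go, is whether carboxy and ethylcarbamoyl stay interchangeable when the nitrogen carries a larger group, a question that a matched pair bearing pentan-3-yl or 4-methoxyphenyl on that nitrogen with each carbonyl group would settle. Also open, from the compounds shown here alone, is how far the carbonyl position tolerates other groups, such as a methyl ester, an unsubstituted amide or a longer chain on the amide nitrogen, since only hydroxy and ethylamino on the carbonyl carbon are compared here.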